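Side-chain swaps on the shared core: compound 4

The source may report more compounds than this note shows. Statements on the series, on what has been measured and on what is new or still open speak of the compounds shown alone.

Measured in a functional assay on the whole organism (Tail, strain ICR) with Mus musculus as the target, in the tail flick test, with a stated time of 150 min, at a dose of 25 umol/kg by the oral route; on this read-out lower numbers stand for a weaker effect and higher numbers for a stronger effect at the one dose given:
- compound 1 `N=C(N)NCCC[C@H](NC(=O)CN(c1nc(Cl)nc2[nH]cnc12)C1CC1)C(=O)OCc1ccccc1`: compound 1 gives 6.12%
- compound 2 `O=C(CN(c1nc(Cl)nc2[nH]cnc12)C1CC1)N[C@@H](CC(=O)OCc1ccccc1)C(=O)OCc1ccccc1`: compound 2 gives 6.68%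
- compound 3 `NCCCC[C@H](NC(=O)CN(c1nc(Cl)nc2[nH]cnc12)C1CC1)C(=O)OCc1ccccc1`: compound 3 gives 9.88%

Compound 3 holds the highest of the three numbers, yet its separations from the others are small: a number 3.8 percentage points higher from compound 1 to compound 3 (within the scatter) and a number 3.2 percentage points higher from compound 2 to compound 3 (within the scatter) both stay within the scatter, as does a number 0.6 percentage points higher from compound 1 to compound 2 (within the scatter). Compound 4 `CSCC[C@H](NC(=O)CN(c1nc(Cl)nc2[nH]cnc12)C1CC1)C(=O)OCc1ccccc1` differs from compound 3 by methylsulfanyl in place of 2-aminoethyl on a saturated chain carbon, three bonds along the chain from an amide-type nitrogen and a carbonyl carbon. The earlier side-chain exchanges on the same chain carbon region bear on this step; none of them moved this assay beyond the scatter. A step of similar size is expected here, so a number 1.9 percentage points lower from compound 3 to compound 4 (within the scatter) is estimated to fall within the scatter. Compound 4 is therefore expected at 8%, with a range from 2% to 15%.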

Compound 4, a percentage reported as activity, at one dose (the size of the read-out at that dose, not a potency): 17.6%
For compound 4 the middle estimate is 9.6 percentage points below the measured one; measured number outside the range, above it.
By their numbers in this assay, from the lowest: compounds 1, 2, 3 and 4 (each within the scatter of the next, the first and the last beyond it).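

In this assay, within the data shown here, the methylsulfanyl exchange gives the first steps in this side-chain set that clear the scatter: a number 10.9 percentage points higher from compound 2 to compound 4 (beyond the scatter) and a number 11.5 percentage points higher from compound 1 to compound 4 (beyond the scatter) lie beyond it, whereas a number 7.7 percentage points higher from compound 3 to compound 4 (within the scatter) stays within it. Compound 4 therefore separates from compound 1 and compound 2, but not from compound 3. No measurement available here accounts for these steps.

The compounds shown leave open whether the sulfur atom itself matters. A methoxy group or a plain alkyl chain in place of methylsulfanyl would test this.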